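A New Aromatic Group on the Carbonyl Carbon

This account rests on a few compounds, and the source may have more. Where it says the series, first, only, none or still open, it means among the compounds named here.

Of the compounds shown here, two sharing one core have numbers so far. In a functional assay on a cell-free system (Platelet, plasma, Homo sapiens) for inhibition (a higher number here means a weaker inhibitor, a lower number a stronger inhibitor), compound 1 `COc1ccc(C(=O)N(CCN2CCC(OCC(=O)O)CC2)c2ccc(C)cc2)cc1` gives 1200 nM and compound 2 `COc1ccc(C(=O)N(CCN2CCC(OCC(=O)O)CC2)c2ccc(Cl)cc2)cc1` gives 3100 nM as the higher of the two numbers, which makes compound 2 the weaker inhibitor of this pair. For the measured compounds named here, the only measured step is a 2.6-fold higher number from compound 1 to compound 2 (0.41 log units; beyond the scatter) and it is modest, with chloro in place of methyl on an aromatic carbon.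

Compound 3 `O=C(O)COC1CCN(CCN(C(=O)c2cccc(C(F)(F)F)c2)c2ccc(Cl)cc2)CC1` keeps the chloro of compound 2 but differs at another place (3-(trifluoromethyl)phenyl in place of 4-methoxyphenyl on a carbonyl carbon) with 3-(trifluoromethyl)phenyl in place of 4-methoxyphenyl on a carbonyl carbon. Going by the values given here, no measured pair shows a change at this carbonyl carbon, so the data give neither a size nor a direction for this swap. Among the compounds with values here, the one step at hand (a 2.6-fold higher number from compound 1 to compound 2 (0.41 log units; beyond the scatter)) lies elsewhere in the molecule and offers only a rough sense of scale. With no direction to go on, the expected outcome is a 1.0-fold lower number from compound 2 to compound 3 (0.01 log units; within the scatter) in this assay with a wide margin either way. For compound 3 the estimated value is 3000 nM with an expected range from 800 nM to 11000 nM around it.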

Compound 3, half-maximal inhibitory concentration: > 10000 nM
Compound 3 gave a limit, no number (the forecaster's own chance of this, stated with the estimate: 3%); middle value at least 3.3-fold (0.52 log units) from the limit.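

For the compounds shown here, the carbonyl carbon now has a measured step, which no earlier pair offered: 3-(trifluoromethyl)phenyl in place of 4-methoxyphenyl gives an at least 3.2-fold higher number from compound 2 to compound 3 (0.50 log units; beyond the scatter) in this assay. The group on this carbonyl carbon therefore matters to inhibition, and this swap moves compound 3 towards weaker inhibition, the same direction as the earlier change from methyl to chloro. From the compounds shown here alone, for compound 3, the reading of > 10000 nM is a limit of the assay and not a number, so only the minimum size of the step can be read, and its full size stays unknown: the limit of > 10000 nM in this assay, at which 1 of the 3 values shown sits.

Going by these compounds alone, the single swap removes the methoxy-bearing ring and brings in the trifluoromethyl-bearing one together, so these compounds cannot show whether losing the first or gaining the second accounts for the step. Going by these compounds, it also remains open how a plain phenyl group, or a phenyl group carrying an amine or a hydroxyl group, would read on this carbonyl carbon, and whether 3-(trifluoromethyl)phenyl would behave the same way with methyl in place of the chloro.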